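A few compounds are considered here, and "the series" means these few. Any claim that something is new, unique, unknown or untested is made for them only; others in the source may bear on it.

Three esters built on the shared core have been measured in a functional assay on K562 cells (Homo sapiens) for inhibition; a higher number here means a weaker inhibitor, a lower number a stronger inhibitor. Compound 1 `CC(CC(=O)OC1C(C(O)CO)OC2OC(C)(C)OC21)c1ccccc1` gives 500000 nM. Compound 2 `CC(C)C(=O)OC1C(C(O)CO)OC2OC(C)(C)OC21` gives 2500000 nM. Compound 3 `CCCCC(=O)OC1C(C(O)CO)OC2OC(C)(C)OC21` gives 2000000 nM, the second highest of the three numbers: its nearest neighbour is compound 2, and the wider gap to compound 1 appears in the step of a 4.0-fold higher number from compound 1 to compound 3 (0.60 log units; beyond the scatter). The step of a 1.3-fold lower number from compound 2 to compound 3 (0.10 log units; within the scatter) shows that swapping one short chain on the carbonyl carbon for another stayed within the scatter.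

Compound 4 `CCC(=O)OC1C(C(O)CO)OC2OC(C)(C)OC21` differs from compound 3 by hydrogen in place of ethyl on a saturated chain carbon, two bonds along the chain from a carbonyl carbon. The chain is simply made shorter. Among the compounds with values here, two measured steps bear on this: the exchange of one short chain for another, which stayed within the scatter, and the replacement of 1-phenylethyl by propyl, which was modest and beyond the scatter. A shorter chain with no ring is expected to leave compound 4 close to compound 3, with any rise in the number staying within the scatter. The expected step is a 1.3-fold higher number from compound 3 to compound 4 (0.10 log units; within the scatter). Compound 4 is therefore estimated at 2500000 nM, within a range from 1000000 nM to 6000000 nM.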

Compound 4, half-maximal inhibitory concentration: 2400000 nM
Estimate against measurement, compound 4: 1.0-fold (0.02 log units) above, within the range that was stated.
By their numbers in this assay, from the lowest: compound 1; then compounds 3, 4 and 2 (each within the scatter of the next).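

Removing ethyl from the saturated chain carbon, two bonds along the chain from a carbonyl carbon, barely registers in this assay: the step is a 1.2-fold higher number from compound 3 to compound 4 (0.08 log units; within the scatter). The isopropyl ester sits level with the shortened chain too, at a 1.0-fold lower number from compound 2 to compound 4 (0.02 log units; within the scatter), so the three esters without a ring cannot be told apart, whether the chain on the carbonyl carbon is butyl, isopropyl or ethyl. Only the ester carrying 1-phenylethyl stands apart from them, and the shortest chain keeps that gap modest, at a 4.8-fold higher number from compound 1 to compound 4 (0.68 log units; beyond the scatter).

No accompanying measurement explains these numbers. Still open, as far as these compounds go, is whether an amine, a carboxylic acid or a longer chain at this place would separate from the short chains, or would reach the number seen with 1-phenylethyl.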